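The source may report more compounds than this note shows. Statements on the series, on what has been measured and on what is new or still open speak of the compounds shown alone.

Measured so far:
- compound 1, `CN(C)CCCNc1nc(-c2ccc(NC(=O)Nc3ccccc3Cl)cc2)nc2c(Cl)c(Cl)sc12`: 490 nM
- compound 2, `Cc1ccc(NC(=O)Nc2ccc(-c3nc(NCCCN(C)C)c4sc(Cl)c(Cl)c4n3)cc2)cc1`: 1110 nM
- compound 3, `CCN(CC)CCCNc1nc(-c2ccc(NC(=O)Nc3ccccc3Cl)cc2)nc2ccsc12`: 200 nM

These three compounds were tested in a functional assay on NCI-H460 cells (Homo sapiens) for cytotoxicity, read by MTT assay, with a stated time of 72 h; on this read-out higher numbers stand for weaker inhibition and lower numbers for stronger inhibition. Compound 1 and compound 2 share a core and differ by 4-methylphenyl in place of 2-chlorophenyl on an amide-type nitrogen; that change gave a 2.3-fold higher number from compound 1 to compound 2 (0.36 log units; beyond the scatter). Compound 3 carries a different core, and the difference between the two cores is not broken down here; in this assay compound 3 gives the lowest number of the three.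

Compound 4, `CCN(CC)CCCNc1nc(-c2ccc(NC(=O)Nc3ccc(C)cc3)cc2)nc2ccsc12`, has not yet been measured. It relates to compound 3 as compound 2 relates to compound 1: the change is 4-methylphenyl in place of 2-chlorophenyl on an amide-type nitrogen, the same change on the same kind of place. If it behaves as before, compound 4 is expected to show a 2.3-fold higher number from compound 3 to compound 4 (0.36 log units; beyond the scatter), because a 2.3-fold higher number from compound 1 to compound 2 (0.36 log units; beyond the scatter). The estimate for compound 4 is therefore 460 nM, expected to lie between 230 nM and 1000 nM.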

Compound 4, half-maximal inhibitory concentration: 1240 nM
The estimate for compound 4 lay 2.7-fold (0.43 log units) below the measured number, outside the stated range (above it).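

In this assay, putting 4-methylphenyl in place of 2-chlorophenyl on the amide-type nitrogen gave a 6.2-fold higher number from compound 3 to compound 4 (0.79 log units; beyond the scatter). The direction of the change carried over from one core to the other, but its size did not: the same change on two cores in this assay, a 2.3-fold higher number (0.36 log units; beyond the scatter) from compound 1 to compound 2 and a 6.2-fold higher number (0.79 log units; beyond the scatter) from compound 3 to compound 4, 2.7-fold (0.44 log units) apart, beyond the scatter of two such steps

The change therefore raised the number on both cores shown, but these two pairs do not show why the size differs or which difference between the cores matters. Going by these compounds, it remains open how the series would respond to a phenyl ring carrying a trifluoromethyl group in place of these two aryl groups. A morpholine in place of the amine on the side chain is also untested among the compounds shown.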